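The source may report more compounds than this note shows. Statements on the series, on what has been measured and on what is new or still open speak of the compounds shown alone.

In a functional assay on SF-268 cells (Homo sapiens) for inhibition, read by sulforhodamine B assay, with a stated time of 48 h, tested at 10 uM (a higher number here means more inhibition of growth at the concentration tested, a lower number less inhibition of growth), three compounds have been measured so far. Compound 1 `COc1ccc(-c2nc3sc(-c4ccccc4)cn3n2)cc1` gives 28%, the highest of the three numbers. Compound 2 `COc1cc(-c2nc3sc(-c4ccccc4)cn3n2)cc(OC)c1OC` gives 9%, and compound 3 `COc1cc(-c2nc(N)n(CC(=O)Nc3ccc(/C(C)=N\O)cc3)n2)cc(OC)c1OC` gives 6.49%. Each of these two stands below compound 1 by more than the usual scatter, while they lie within the scatter of each other.

The next compound to be tested is compound 4 `COc1ccc(-c2nc3sc(-c4ccc(Cl)cc4)cn3n2)cc1`, which differs from compound 1 at a single place: chloro in place of hydrogen on an aromatic carbon. Among the measured compounds shown here, none of the measured compounds carries this change, and no pair among them differs in one place, so the data offer no direct guide to its size. As far as these compounds go, the expectation therefore stays close to compound 1 at 28%, with a small rise in this assay that is not clearly beyond the scatter, though a wide range remains open in either direction. The expected step is a number 3 percentage points higher from compound 1 to compound 4 (within the scatter). For compound 4 the estimate is 31%, with an expected range of 12% to 50%.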

Compound 4, percent growth inhibition at one concentration: 34.9%
Compound 4: the middle estimate sits 3.9 percentage points below what was measured; low and high end bracket the measured number.
By their numbers in this assay, from the lowest: compounds 3 and 2 (each within the scatter of the next); then compounds 1 and 4 (each within the scatter of the next).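

In this assay, among the compounds shown here, the change from phenyl to 4-chlorophenyl reads as a number 6.9 percentage points higher from compound 1 to compound 4 (within the scatter) and is the first step in this set taken between two compounds that differ in one place. It shows that this aromatic carbon, para to a large group, can carry a chloro in place of hydrogen without a change in growth inhibition that stands clear of the usual scatter, so compound 1 and compound 4 cannot be told apart at the single concentration tested. The result therefore marks this position as open to a single chlorine atom, but it does not show that chloro brings any gain, and no measurement is at hand to explain the outcome in either direction.

As far as these compounds go, whether a different group at this same place, such as an amine, a carboxylic acid or a longer chain, would move the number beyond the scatter remains open. Also open, from the compounds shown here alone, is whether chloro in place of hydrogen would give a similar step on compound 2, since this single pair speaks only for the core and the methoxy pattern of compound 1.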